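A few compounds are considered here, and "the series" means these few. Any claim that something is new, unique, unknown or untested is made for them only; others in the source may bear on it.

Compound 1 `Cc1ccccc1/N=C1\NC(=O)/C(=C\c2ccc(N(C)C)cc2)S1` is the anchor of this small set. In a functional assay on NCI-H460 cells (Homo sapiens) for antiproliferative activity (a higher number here means a weaker inhibitor, a lower number a stronger inhibitor), compound 1 gives 650 nM, the lowest of the three numbers measured; compound 2 `COc1ccc(N=C2NC(=O)/C(=C\c3ccc(N(C)C)cc3)S2)cc1` gives 2520 nM and compound 3 `CN(C)c1ccc(/C=C2/S/C(=N/c3ccc(Cl)cc3)NC2=O)cc1` gives 2890 nM, both well outside the usual scatter from compound 1. Among the measured compounds shown here, the only single-place step in this set, a 4.4-fold higher number from compound 1 to compound 3 (0.65 log units; beyond the scatter), changes the group on the double-bonded nitrogen. Compound 4 `COc1ccc(/C=C2/S/C(=N/c3ccccc3C)NC2=O)cc1` alters a different part of compound 1: methoxy in place of dimethylamino on an aromatic carbon. For the measured compounds named here, no measured step touches that position, so there is no direct precedent in this assay for the swap. Since every change away from compound 1 so far has raised the number, a modest rise is expected, as a 2.5-fold higher number from compound 1 to compound 4 (0.39 log units; beyond the scatter); compound 4 is estimated at 1600 nM, within 500 nM to 5000 nM.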

Compound 4, half-maximal inhibitory concentration: 1780 nM
Estimate against measurement, compound 4: 1.1-fold (0.05 log units) below; low and high end bracket the measured number.
By their numbers in this assay, from the lowest: compound 1; then compounds 4, 2 and 3 (each within the scatter of the next).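

Swapping dimethylamino for methoxy on the aromatic carbon para to a large group gives a 2.7-fold higher number from compound 1 to compound 4 (0.44 log units; beyond the scatter) and is the first measured evidence that this position affects the number. Both groups have no ring, no net charge, and matching hydrogen-bond donor and acceptor counts, so those counts do not distinguish them. No available evidence explains the rise.

From the compounds shown here alone, how a hydroxyl, a primary amine or an ethoxy group would behave at this position remains open. So does whether methoxy would produce a similar rise with 4-chlorophenyl on the double-bonded nitrogen.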